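This account rests on a few compounds, and the source may have more. Where it says the series, first, only, none or still open, it means among the compounds named here.

Measured in a functional assay on MCF7 cells (Homo sapiens) for antiproliferative activity, read by MTT assay, with a stated time of 72 h; a lower number here means a stronger inhibitor, a higher number a weaker inhibitor:
- Compound 1 `COc1ccc(-c2ncnn2-c2cc(OC)c(OC)c(OC)c2)cc1`: 360 nM
- Compound 2 `COc1cccc(-c2ncnn2-c2cc(OC)c(OC)c(OC)c2)c1`: > 10000 nM, a limit
- Compound 3 `COc1cc(-n2ncnc2-c2cccc([N+](=O)[O-])c2)cc(OC)c1OC`: > 10000 nM, a limit

Compound 2 gives only a limit, > 10000 nM, and the series shows (the limit of > 10000 nM in this assay, at which 2 of the 3 values shown sit). Compound 4 `COc1ccccc1-c1ncnn1-c1cc(OC)c(OC)c(OC)c1` has 2-methoxyphenyl in place of the 3-methoxyphenyl of compound 2: 2-methoxyphenyl in place of 3-methoxyphenyl on an aromatic carbon. The closest measured change is an at least 27-fold higher number from compound 1 to compound 2 (1.44 log units; beyond the scatter), a large step with 3-methoxyphenyl in place of 4-methoxyphenyl. The other measured change, a step that the two limits leave unreadable from compound 2 to compound 3, gives no readable size. Compound 4 also lacks the 4-methoxyphenyl of compound 1, at 360 nM, so no clear gain is expected in this assay. The expected result is a number no higher from compound 2 to compound 4 (the limit leaves the size open), with no step beyond the scatter. The estimated value for compound 4 is 10000 nM, with an expected range from 2500 nM to 40000 nM.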

Compound 4, half-maximal inhibitory concentration: > 10000 nM
Compound 4 ended at the assay's limit; the forecaster's own chance of this, stated with the estimate: 65%; the middle value lies on the limit itself.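

Replacing 4-methoxyphenyl with 2-methoxyphenyl on this aromatic carbon gives an at least 27-fold higher number from compound 1 to compound 4 (1.44 log units; beyond the scatter) in this assay and so adds a second methoxyphenyl change with a large loss. Among the three methoxyphenyl compounds, only the 4-methoxyphenyl of compound 1 gives a readable number. The steps between compounds at the limit cannot be read, so compound 2, compound 3 and compound 4 cannot be ranked: the limit of > 10000 nM in this assay, at which 3 of the 4 values shown sit.

Left open is whether an ethoxy group or an amine in place of the methoxy of compound 1 would keep a readable number in this assay at this place.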